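This account rests on a few compounds, and the source may have more. Where it says the series, first, only, none or still open, it means among the compounds named here.

Measured in a functional assay on MCF7 cells (Homo sapiens) for cytotoxicity, read by MTT assay, with a stated time of 72 h; a lower number here means a stronger inhibitor, a higher number a weaker inhibitor:
- compound 1 `Cc1oc2ncnc(Nc3cccc(Br)c3)c2c1C(=O)O`: 68000 nM
- compound 2 `Cc1oc2ncnc(Nc3cccc(Cl)c3)c2c1C(=O)NCCO`: > 1000000 nM
- compound 3 `CCOC(=O)c1c(C)oc2ncnc(Nc3cccc(Br)c3)c12`: > 1000000 nM

Only compound 1 has an actual number. Compound 3 gives > 1000000 nM, and this is a limit of the assay, not a number. Compound 3 therefore sits at the limit of > 1000000 nM in this assay, at which 2 of the 3 values shown sit, and its exact place cannot be read.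

Compound 4 `Cc1oc2ncnc(Nc3cccc(Br)c3)c2c1C(=O)NCCO` differs from compound 3 by a single change, ((2-hydroxyethyl)amino in place of ethoxy on a carbonyl carbon). In words, this is (2-hydroxyethyl)amino in place of ethoxy on a carbonyl carbon.

One measured step involves that carbonyl group: an at least 14-fold higher number from compound 1 to compound 3 (1.16 log units; beyond the scatter). It is large, but it links compound 3 to compound 1, and no amide takes part in it. It sets no size for the change here.

Compound 2 is the closer guide, since it carries the same (2-hydroxyethyl)amino on its carbonyl carbon, though it differs from compound 4 elsewhere. Compound 2 gives > 1000000 nM, which is also a limit.

On that evidence, no step beyond the scatter is expected in this assay, and a move in either direction cannot be told in advance. The expected step is a number no higher from compound 3 to compound 4 (the limit leaves the size open). For compound 4 the estimate is 1000000 nM, with an expected range of 250000 nM to 4000000 nM.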

Compound 4, half-maximal inhibitory concentration: 22000 nM
Compound 4: the middle estimate sits 45-fold (1.66 log units) above what was measured; measured number outside the range, below it.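

In this assay, this carbonyl position turns out to respond strongly to what is attached to it, with (2-hydroxyethyl)amino in place of ethoxy giving an at least 45-fold lower number from compound 3 to compound 4 (1.65 log units; beyond the scatter), and the halogen also matters once this amide is present, with bromo in place of chloro on an aromatic carbon giving an at least 45-fold lower number from compound 2 to compound 4 (1.65 log units; beyond the scatter). Both steps start from a limit of the assay and not from a number, so their full size cannot be read: the limit of > 1000000 nM in this assay, at which 2 of the 4 values shown sit. For the compounds shown here, the one step between two actual numbers is smaller but still beyond the scatter, with (2-hydroxyethyl)amino in place of hydroxy on the carbonyl carbon giving a 3.1-fold lower number from compound 1 to compound 4 (0.49 log units; beyond the scatter), so this amide, not the carboxylic acid, now carries the lowest number of the four compounds.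

The compounds shown leave open whether the hydroxy group at the end of the (2-hydroxyethyl)amino chain plays any part in this gain, since none of them has a plain ethylamino group or an amine in its place. They also leave open what a longer chain, such as 3-hydroxypropylamino, would do on the same carbonyl carbon.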